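The compounds below may be only part of what the source reports. "The series", "measured", "known", "first", "only" and "open" are said of these compounds alone.

Measured so far in a physicochemical assay for lipophilicity, read by HPLC, measured as chromatographic lipophilicity, at pH 7.4; a higher number here means a more lipophilic compound, a lower number a more polar compound:
- compound 1, `O=C(C1CCN(c2ccncn2)CC1)N1N=CC[C@H]1c1ccccc1`: compound 1 gives 3.2
- compound 2, `CC(C)(C)C(=O)N1CCNCC1c1ccccc1`: compound 2 gives 2.5
- compound 3, `CC(C)(C)C(=O)N1N=CCC1c1cocn1`: compound 3 gives 3

Compound 3 sits second highest of the three numbers in this assay. Its value and that of compound 1 lie within the scatter of each other, so no order between the two can be read from these numbers. Compound 2 lies lower than compound 3 by a margin beyond the scatter.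

The next compound in the series is compound 4, `CC(C)(C)C(=O)N1N=CCC1c1c[nH]cn1`. It differs from compound 3 in one place: 1H-imidazol-4-yl in place of 1,3-oxazol-4-yl on a saturated ring carbon

Going by the values given here, no pair among the measured compounds differs in only this place, so the size of this step has not been seen directly. The expectation is nonetheless a downward move beyond the scatter. Compound 4 is expected to give about 2 in this assay, with a likely range from 1.4 to 2.6. That estimate corresponds to an expected step of a number 1.00 log units lower from compound 3 to compound 4 (beyond the scatter), downward and larger than the scatter.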

Compound 4, distribution coefficient: 1.7
Estimate against measurement, compound 4: 0.30 log units above; the range from low to high includes it.
By their numbers in this assay, from the lowest: compound 4; then compound 2; then compounds 3 and 1 (each within the scatter of the next).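

In this assay, the series now has its first step that differs in one place: 1H-imidazol-4-yl in place of 1,3-oxazol-4-yl on a saturated ring carbon reads a number 1.30 log units lower from compound 3 to compound 4 (beyond the scatter). This position therefore tells apart two groups that share much in the count: each is a five-membered aromatic ring with 2 hetero atoms and 5 heavy atoms, while the entering group has 1 hydrogen-bond donor and the leaving group has 0 hydrogen-bond donors. Nothing at hand gives a reason for the size of this step.

Open, going by these compounds, is whether the step follows the ring hydrogen on nitrogen, as a 1-methyl-1H-imidazol-4-yl group at the same carbon could test. Also open, on these data alone, is whether the same change reads alike on the core of compound 1.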